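Exchanging the end group on a growth-inhibiting series

A few compounds are considered here, and "the series" means these few. Any claim that something is new, unique, unknown or untested is made for them only; others in the source may bear on it.

Compound 1 `Oc1cccc2[nH]c(-c3ccc(-c4ccc(-c5ccccc5)cc4)cc3)nc12` gives 4010 nM
Compound 2 `Oc1cccc2[nH]c(-c3ccc(-c4ccc(-c5ccc(C(F)(F)F)cc5)cc4)cc3)nc12` gives 4320 nM
Compound 3 `CN(C)c1ccc(-c2ccc(-c3ccc(-c4nc5c(O)cccc5[nH]4)cc3)cc2)cc1` gives 4200 nM

In a functional assay on KB cells (Homo sapiens) for inhibition, read by sulforhodamine B assay (a higher number here means a weaker inhibitor of growth, a lower number a stronger inhibitor of growth), compound 3 stands with the other two, its value within the scatter of both. Compound 4 `Oc1cccc2[nH]c(-c3ccc(-c4ccc(-c5cccc(Cl)c5)cc4)cc3)nc12` differs from it by one exchange 3-chlorophenyl in place of 4-(dimethylamino)phenyl on an aromatic carbon at that same end of the molecule. Going by the values given here, three measured steps bear on this: a 1.1-fold higher number from compound 1 to compound 2 (0.03 log units; within the scatter) and a 1.0-fold higher number from compound 1 to compound 3 (0.02 log units; within the scatter) and also a 1.0-fold lower number from compound 2 to compound 3 (0.01 log units; within the scatter) all lie within the scatter. Among the compounds with values here, no measured compound carries 3-chlorophenyl, so this group remains untested. The expected step of a 1.0-fold lower number from compound 3 to compound 4 (0.01 log units; within the scatter) is therefore none beyond the scatter. For compound 4 the estimated value is 4100 nM with an expected range from 2200 nM to 7500 nM in all.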

Compound 4, concentration for 50% growth inhibition: 2280 nM
Compound 4: the middle estimate sits 1.8-fold (0.25 log units) above what was measured, and the stated range covers the measured number.
By their numbers in this assay, from the lowest: compounds 4, 1, 3 and 2 (each within the scatter of the next).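

In this assay, 3-chlorophenyl at this end of the molecule gives a 1.8-fold lower number from compound 3 to compound 4 (0.27 log units; within the scatter), a 1.9-fold lower number from compound 2 to compound 4 (0.28 log units; within the scatter), and a 1.8-fold lower number from compound 1 to compound 4 (0.25 log units; within the scatter). Across the four compounds, this position has now carried four different phenyl groups, including one with chloro rather than hydrogen, and no step among them goes beyond the scatter. No available evidence accounts for these steps.

As far as these compounds go, whether a carboxylic acid, a primary amine or a longer chain at this position would give a step beyond the scatter remains open.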